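A few compounds are considered here, and "the series" means these few. Any claim that something is new, unique, unknown or untested is made for them only; others in the source may bear on it.

Going by the values given here, in a functional assay on A549 cells (Homo sapiens) for inhibition, read by MTT assay, with a stated time of 48 h (a higher number here means a weaker inhibitor, a lower number a stronger inhibitor), compound 1 (`COc1ccc(-c2nc3ccccn3c2Sc2ccccc2)cc1`) gives 58400 nM, the highest of the three numbers measured so far. Compound 2 (`c1ccc(Sc2c(-c3cccc4ccccc34)nc3ccccn23)cc1`) gives 17900 nM and compound 3 (`CS(=O)(=O)c1ccc(-c2nc3ccccn3c2Sc2cccc3ccccc23)cc1`) gives 19600 nM, both lower than compound 1 by more than the scatter. Compound 4 (`c1ccc(Sc2c(-c3ccsc3)nc3ccccn23)cc1`) has thiophen-3-yl in place of 4-methoxyphenyl on an aromatic carbon. Among the compounds with values here, no measured pair shows this change alone, so any expectation for this assay is loose. Compound 2 and compound 3 both lack 4-methoxyphenyl and both sit lower, which suggests a moderate fall rather than a rise. The expected step is a 1.7-fold lower number from compound 1 to compound 4 (0.22 log units; within the scatter). Compound 4 is estimated at 35000 nM, with an expected range of 13000 nM to 90000 nM.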

Compound 4, half-maximal inhibitory concentration: 72900 nM
Estimate against measurement, compound 4: 2.1-fold (0.32 log units) below, and the stated range covers the measured number.
By their numbers in this assay, from the lowest: compounds 2 and 3 (each within the scatter of the next); then compounds 1 and 4 (each within the scatter of the next).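

On this aromatic carbon, thiophen-3-yl in place of 4-methoxyphenyl gives a 1.2-fold higher number from compound 1 to compound 4 (0.10 log units; within the scatter) in this assay, so the two groups read alike in the only single-place comparison shown. Losing 4-methoxyphenyl from this position is therefore not enough by itself to lower the number. Nothing available explains this result. The compounds shown leave open whether an amine or a carboxylic acid on this carbon would move the number beyond the scatter. They also leave open how much the phenylsulfanyl group contributes.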